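A few compounds are considered here, and "the series" means these few. Any claim that something is new, unique, unknown or untested is made for them only; others in the source may bear on it.

Measured in a functional assay on MCF7 cells (Homo sapiens) for antiproliferative activity, read by MTT assay, with stated times of 24 h and 72 h; a lower number here means a stronger inhibitor, a higher number a weaker inhibitor:
- compound 1 `COc1cc([C@@H]2[C@H](Oc3ccccc3)C(=O)N2c2cc(OC)c(OC)c(OC)c2)ccc1O`: 32000 nM
- compound 2 `COc1cc([N+](=O)[O-])c([C@@H]2[C@H](Oc3ccccc3)C(=O)N2c2cc(OC)c(OC)c(OC)c2)cc1O`: 59000 nM

Compound 2 gives 59000 nM, and this cannot be told apart from compound 1, at 32000 nM. Among the measured compounds shown here, the only measured step, a 1.8-fold higher number from compound 1 to compound 2 (0.27 log units; within the scatter), lies within the scatter.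

The next compound, compound 3 `COc1ccc([C@@H]2[C@H](Oc3ccccc3)C(=O)N2c2cc(OC)c(OC)c(OC)c2)c(N)c1O`, is not yet measured. It differs from compound 2 by a group of 10 heavy atoms (7 carbon, 1 nitrogen, 2 oxygen; one six-membered aromatic ring of carbon only) in place of a group of 12 heavy atoms (7 carbon, 1 nitrogen, 4 oxygen; one six-membered aromatic ring of carbon only), on a saturated ring carbon, on a saturated ring carbon of a four-membered non-aromatic ring with 1 nitrogen. The measured step changes a group at this same ring carbon, but it does not cover the group entering here, so it sets no firm size or direction for this assay. A move to a lower number is expected only tentatively, with a wide margin. The estimated change is a 5.9-fold lower number from compound 2 to compound 3 (0.77 log units; beyond the scatter). For compound 3 the expected value is 10000 nM, within an estimated range of 300 nM to 70000 nM.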

Compound 3, half-maximal inhibitory concentration: 19000 nM
For compound 3 the middle estimate is 1.9-fold (0.28 log units) below the measured one; the measured number falls inside the stated range.
By their numbers in this assay, from the lowest: compounds 3, 1 and 2 (each within the scatter of the next, the first and the last beyond it).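

Among the compounds shown here, at the saturated ring carbon of the four-membered non-aromatic ring, the aromatic group now gives a first step beyond the scatter in this assay (a 3.1-fold lower number from compound 2 to compound 3 (0.49 log units; beyond the scatter)), so the group entering in compound 3 separates from the group in compound 2, though only modestly. The same position shows no such separation against the group in compound 1 (a 1.7-fold lower number from compound 1 to compound 3 (0.23 log units; within the scatter)), so the amino-bearing group cannot be ranked against the group without nitrogen. No measurement at hand accounts for either step.

The three compounds do not show whether the step comes from the nitrogen substituent alone, as the two groups also differ in how their substituents are arranged. Going by these compounds, whether an acetamide or a carboxylic acid at this aromatic ring would extend the step also remains open.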